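From ethoxycarbonyl to methoxycarbonyl on a shared core

This account rests on a few compounds, and the source may have more. Where it says the series, first, only, none or still open, it means among the compounds named here.

In a functional assay on MCF7 cells (Homo sapiens) for inhibition, read by sulforhodamine B assay, with a stated time of 72 h (a lower number here means a stronger inhibitor of growth, a higher number a weaker inhibitor of growth), compound 1 (`CNC(=O)/C=C/c1ccncc1-c1ccc2cc[nH]c2c1`) gives 9230 nM and compound 2 (`CCOC(=O)/C=C/c1ccncc1-c1ccc2ccccc2c1`) gives 8320 nM as its value. These two numbers lie within the usual scatter of each other, so compound 2 stands level with compound 1 and neither can be called the better inhibitor. Compound 3 (`COC(=O)/C=C/c1ccncc1-c1ccc2ccccc2c1`) has not yet been measured. It differs from compound 2 in one small place (hydrogen in place of methyl on a saturated chain carbon bound to an oxygen next to a carbonyl group): hydrogen in place of methyl on a saturated chain carbon bound to an oxygen next to a carbonyl group, which turns ethyl into methyl and ethoxycarbonyl into methoxycarbonyl. Among the compounds with values here, no measured pair shows this change, so the data offer no direct guide. A shift within the scatter is expected, and the estimated 1.0-fold lower number from compound 2 to compound 3 (0.02 log units; within the scatter) amounts to no real change. Compound 3 is therefore expected at 8000 nM within a range from 3500 nM to 18000 nM in this estimate.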

Compound 3, concentration for 50% growth inhibition: 8170 nM
Beside the measured number, compound 3's estimate is 1.0-fold (0.01 log units) below it; the range from low to high includes it.
By their numbers in this assay, from the lowest: compounds 3, 2 and 1 (each within the scatter of the next).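

Within the data shown here, this is the first pair among the measured compounds that differs in only one place: in this assay, the ethoxycarbonyl and methoxycarbonyl groups are compared directly, giving a 1.0-fold lower number from compound 2 to compound 3 (0.01 log units; within the scatter). Replacing this methyl with hydrogen, on a saturated chain carbon bound to an oxygen next to a carbonyl group, therefore leaves the two compounds level, and this pair gives no basis for preferring ethyl or methyl here. The information available offers no explanation for this result.

Still open, from the compounds shown here alone, is whether a longer chain, such as propyl or butyl, would also stay level at this place. Going by these compounds, it is also open how a carboxylic acid would read on the shared core, with the hydrogen of the acid in place of the whole ethyl or methyl group.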